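Butyl in place of cyclohexenyl: expected antiproliferative potency

The compounds below may be only part of what the source reports. "The series", "measured", "known", "first", "only" and "open" are said of these compounds alone.

In a functional assay on MCF7 cells (Homo sapiens) for antiproliferative activity, read by MTT assay, with a stated time of 72 h (on this read-out higher numbers stand for weaker inhibition and lower numbers for stronger inhibition), compound 1 `Cc1ccc(-c2cn(Cc3ccccc3)nn2)cc1` gives 253000 nM. Compound 2 `C1=C(c2cn(Cc3ccccc3)nn2)CCCC1` is reported only as a limit, > 100000 nM, and so stands at the limit of > 100000 nM in this assay, at which 1 of the 2 values shown sits. Among the compounds with values here, no step between the two measured compounds can be stated, only that both sit at the weak end of this assay. Compound 3 `CCCCc1cn(Cc2ccccc2)nn1` differs from compound 2 by butyl in place of cyclohex-1-en-1-yl on an aromatic carbon. No shift beyond the scatter is expected, a step that the limit leaves unreadable from compound 2 to compound 3. Compound 3 is therefore estimated at 200000 nM, within 60000 nM to 600000 nM, with a fair chance that this assay again reports only a limit.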

Compound 3, half-maximal inhibitory concentration: > 100000 nM
Compound 3: no number, only a limit; the forecaster's own chance of this, stated with the estimate: 65%; the middle value lies beyond the limit too.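

No step from compound 2 to compound 3 can be read, because both are reported only as limits: the limit of > 100000 nM in this assay, at which 2 of the 3 values shown sit.

The compounds shown leave open how butyl and cyclohex-1-en-1-yl compare once both give a measurable value.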